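Adding methoxymethoxy to a compound at the assay limit

A few compounds are considered here, and "the series" means these few. Any claim that something is new, unique, unknown or untested is made for them only; others in the source may bear on it.

Compound 1 `COc1ccc(C2=C(c3cc(OC)c(OC)c(OC)c3)C(=O)CC2O[SiH2]C(C)(C)C)cc1` gives > 100 ug/mL as a limit
Compound 2 `COc1cc(C2=C(c3cc(C)c(OC)c(C)c3)C(O)CC2=O)cc(OC)c1OC` gives > 100 ug/mL as a limit
Compound 3 `COc1ccc(C2=C(c3cc(OC)c(OC)c(OC)c3)C(=O)CC2O)cc1` gives > 100 ug/mL as a limit

In an ADME assay on MIA PaCa-2 cells (Homo sapiens) for cytotoxicity, read by MTT assay, with a stated time of 72 h (on this read-out higher numbers stand for weaker inhibition and lower numbers for stronger inhibition), compound 1 gives > 100 ug/mL as its result, which is a limit and not a number. What is known so far is the limit of > 100 ug/mL in this assay, at which 3 of the 3 values shown sit, and so compound 1 has no measured rank among the others.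

Among the measured compounds shown here, compound 4 `COCOc1cc(C2=C(c3cc(OC)c(OC)c(OC)c3)C(=O)CC2O[SiH2]C(C)(C)C)ccc1OC` differs from compound 1 by methoxymethoxy in place of hydrogen on an aromatic carbon as its one change: methoxymethoxy in place of hydrogen on an aromatic carbon, ortho to a methoxy group. The 4-methoxyphenyl thus becomes 4-methoxy-3-(methoxymethoxy)phenyl.

For the measured compounds named here, only one measured step starts from compound 1, namely a step that the two limits leave unreadable from compound 1 to compound 3 and it concerns an oxygen on a saturated carbon, not this aromatic carbon. Going by the values given here, it offers no size to carry over, and no measured step tests the new group.

No change beyond the usual scatter can therefore be expected in this assay and no direction can be argued. The expected outcome is a step that the limit leaves unreadable from compound 1 to compound 4 as an estimate resting on no measured size. For compound 4 the estimated value is 120 ug/mL with an expected range from 60 ug/mL to 250 ug/mL and a limit is again the likeliest report.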

Compound 4, half-maximal inhibitory concentration: 50 ug/mL
Beside the measured number, compound 4's estimate is 2.4-fold (0.38 log units) above it; measured number outside the range, below it.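

Placing methoxymethoxy on this aromatic carbon, ortho to a methoxy group, gives in this assay an at least 2.0-fold lower number from compound 1 to compound 4 (0.30 log units; that floor lies within the scatter) and so makes this the first position in the series where a single change yields a measurable result. Among the compounds shown here, earlier compounds offered no such reading, and the one other step from compound 1 concerns an oxygen on a saturated carbon and cannot be read. For the compounds shown here, compound 4, at 50 ug/mL, is the only compound here with a number and not a limit, which is what sets it apart from the rest of the set: the limit of > 100 ug/mL in this assay, at which 3 of the 4 values shown sit.

Even so, the floor of this step lies within the usual scatter, so the step alone does not establish a real gain. The compounds shown leave open whether methoxymethoxy itself matters or whether another group on this carbon, such as a hydroxyl, an amine, a carboxylic acid or a longer ether chain, would give a similar or lower number, and whether the same change would also register on compound 3, which has a free hydroxyl in place of the silyl ether.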